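This account rests on a few compounds, and the source may have more. Where it says the series, first, only, none or still open, it means among the compounds named here.

Measured compounds:
compound 1, `O=C(O)COc1ccc(NC(=O)C2(C(=O)Nc3ccccc3)CC2)cc1F`, 13.6%
compound 2, `CCOc1ccccc1OC(C)C(=O)Nc1ccc(OCC(=O)O)c(F)c1`, 8.79%
compound 3, `CCc1ccc(OCC(=O)Nc2ccc(OCC(=O)O)c(F)c2)cc1`, 14.6%

Three compounds sharing a common core were tested in a functional assay on CHO cells for agonist activity at Free fatty acid receptor 1 (Homo sapiens), read by FLIPR, tested at 100 nM; on this read-out higher numbers stand for a stronger effect at the one concentration tested and lower numbers for a weaker effect. Compound 1 gives 13.6%, compound 2 gives 8.79%, and compound 3 gives 14.6%. Compound 2 holds the lowest of the three numbers, but its gap to compound 1 and its gap to compound 3 both lie within the scatter of repeated measurements, so the three readings cannot be told apart on this evidence and none of them can be called the weakest or the strongest.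

The next compound, compound 4, `Cc1ccc(C)c(OC(C)C(=O)Nc2ccc(OCC(=O)O)c(F)c2)c1`, has not yet been measured in this assay. Compared with compound 2 the change is 2,5-dimethylphenyl in place of 2-ethoxyphenyl on an oxygen on a saturated carbon.

Among the measured compounds shown here, no pair of measured compounds differs in a single place, so there is no measured step on which to rest a prediction for this change. The three values all sit close together, and nothing in them points in either direction. The expected step from compound 2 to compound 4 is therefore a number 4.2 percentage points higher from compound 2 to compound 4 (within the scatter), which means no change beyond the scatter. Compound 4 is estimated to give 13% in this assay, with a likely range from 4% to 28%.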

Compound 4, a percentage reported as activity, at one concentration (the size of the read-out at that concentration, not a potency): 18.7%
Beside the measured number, compound 4's estimate is 5.7 percentage points below it, within the range that was stated.
By their numbers in this assay, from the lowest: compounds 2, 1, 3 and 4 (each within the scatter of the next).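

In this assay, among the compounds shown here, putting 2,5-dimethylphenyl in place of 2-ethoxyphenyl on an oxygen on a saturated carbon gives a number 9.9 percentage points higher from compound 2 to compound 4 (within the scatter), and this is the first change in the set that can be read at a single place with everything else held the same. It shows that this position accepts a swap from a substituted ring carrying one hydrogen-bond acceptor to a substituted ring carrying none, with a smaller heavy-atom count, and that the read-out at the one concentration tested does not move beyond the usual scatter of repeated measurements. Nothing measured here bears on why the two compounds read as they do.

For the compounds shown here, with only this one pair, it remains open whether any group at this position can move the read-out beyond the scatter, for instance a chlorine, a trifluoromethyl or an amine on the aromatic ring, or a pyridine ring in place of the benzene ring. As far as these compounds go, it also remains open whether the same swap would show a clearer difference in a full concentration series, since a single concentration gives no potency.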